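Compound 3 to compound 4: ethoxycarbonyl for cyano

A few compounds are considered here, and "the series" means these few. Any claim that something is new, unique, unknown or untested is made for them only; others in the source may bear on it.

- compound 1 `COC(=O)c1cccc(-c2ccc(-n3cccc3)nn2)c1` gives > 25000 nM as a limit
- compound 2 `COc1ccc(Nc2ccc(-c3ccccc3)nn2)cc1` gives > 25000 nM as a limit
- compound 3 `CCN(CC)c1ccc(-c2ccc(C#N)cc2)nn1` gives > 25000 nM as a limit

In an ADME assay on HaCaT cells (Homo sapiens) for antiproliferative activity, with a stated time of 48 h (on this read-out lower numbers stand for stronger inhibition and higher numbers for weaker inhibition), compound 3 gives > 25000 nM as a limit and not as a number. The whole measured set stands at the limit of > 25000 nM in this assay, at which 3 of the 3 values shown sit, and so offers no numerical value to rank. Going by the values given here, no pair of measured compounds differs in one place, so no measured step is available as a guide.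

Compound 4 `CCOC(=O)c1ccc(-c2ccc(N(CC)CC)nn2)cc1` is not yet measured. It carries ethoxycarbonyl in place of the cyano of compound 3, on an aromatic carbon of a six-membered aromatic ring of carbon only, para to a large group (ethoxycarbonyl in place of cyano on an aromatic carbon).

In this assay the expected step of a number no higher from compound 3 to compound 4 (the limit leaves the size open) is none beyond the scatter, in either direction. The expected value for compound 4 is 25000 nM within an estimated range of 8000 nM to 60000 nM and is likely to be reported as a limit.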

Compound 4, half-maximal inhibitory concentration: 500 nM
Compound 4: the middle estimate sits 50-fold (1.70 log units) above what was measured; the whole stated range lies above it.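

In this assay, going by these compounds alone, the exchange of cyano for ethoxycarbonyl on an aromatic carbon, para to a large group, gives an at least 50-fold lower number from compound 3 to compound 4 (1.69 log units; beyond the scatter), so this position responds to its substituent, which the earlier compounds could not show. Within the data shown here, compound 4 is the only member of the set with a number, giving the series its first reference point for ranking: the limit of > 25000 nM in this assay, at which 3 of the 4 values shown sit. The step rests on this single pair and is read on one core only.

From the compounds shown here alone, whether the effect needs the whole ester stays open: a carboxylic acid, a primary amide or a longer alkyl ester at this position would separate the carbonyl from the ethyl chain. Equally open, going by these compounds, is what a cyclic amine such as morpholine would do in place of the other substituent of compound 4.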